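A few compounds are considered here, and "the series" means these few. Any claim that something is new, unique, unknown or untested is made for them only; others in the source may bear on it.

Measured compounds:
- compound 1 `O=S(=O)(c1ccc(F)c(Cl)c1)c1cnc2cc(F)ccc2c1-c1cccc(F)c1`: 0.25 mL/min
- compound 2 `O=S(=O)(c1ccc(F)cc1)c1cnc2cc(F)ccc2c1-c1cccc(F)c1`: 0.95 mL/min
- compound 3 `Cc1ccc(S(=O)(=O)c2cnc3cc(F)ccc3c2-c2cccc(F)c2)cc1C`: 3.71 mL/min

In an ADME assay on microsomes from liver (Homo sapiens) for metabolic stability, tested at 2.5 uM (on this read-out higher numbers stand for fast clearance and lower numbers for slow clearance), compound 3 gives 3.71 mL/min, the highest of the three numbers; the steps of a 3.9-fold higher number from compound 2 to compound 3 (0.59 log units; beyond the scatter) and a 15-fold higher number from compound 1 to compound 3 (1.17 log units; beyond the scatter) both lie beyond the scatter. Compound 4 `Cc1ccc(S(=O)(=O)c2cnc3cc(F)ccc3c2-c2cccc(F)c2)cc1F` differs from compound 3 by fluoro in place of methyl on an aromatic carbon. Going by the values given here, the steps that bear on this are a 3.9-fold higher number from compound 2 to compound 3 (0.59 log units; beyond the scatter) and a 15-fold higher number from compound 1 to compound 3 (1.17 log units; beyond the scatter), where the 3,4-dimethylphenyl group carried the higher number in each case. Taking one methyl away for a fluoro is expected to reverse part of that, so a modest step downward a 2.1-fold lower number from compound 3 to compound 4 (0.31 log units; beyond the scatter) is expected. Compound 4 is therefore estimated at 1.8 mL/min, with a range of 0.9 mL/min to 3.7 mL/min.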

Compound 4, intrinsic clearance in a liver preparation (reported as CLH), per the amount of preparation that the assay uses: 0.41 mL/min
For compound 4 the middle estimate is 4.4-fold (0.64 log units) above the measured one, outside the stated range (below it).
By their numbers in this assay, from the lowest: compounds 1 and 4 (each within the scatter of the next); then compound 2; then compound 3.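

In this assay, the change from 3,4-dimethylphenyl to 3-fluoro-4-methylphenyl alone gives a 9.0-fold lower number from compound 3 to compound 4 (0.96 log units; beyond the scatter), so this single position strongly moves the read-out even with the other methyl retained. The 3-fluoro-4-methylphenyl group also gives a 2.3-fold lower number from compound 2 to compound 4 (0.36 log units; beyond the scatter) against 4-fluorophenyl, while against 3-chloro-4-fluorophenyl it gives a 1.6-fold higher number from compound 1 to compound 4 (0.21 log units; within the scatter), leaving those two groups unseparated. No available measurement accounts for these steps.

Open, from the compounds shown here alone, is how other groups at this position would read, such as methoxy, nitrile or an amine. Also open, going by these compounds, is 4-methylphenyl, with hydrogen at this position.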